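A few compounds are considered here, and "the series" means these few. Any claim that something is new, unique, unknown or untested is made for them only; others in the source may bear on it.

Measured in a functional assay, read by spectrophotometry; on this read-out lower numbers stand for an effect already at smaller amounts and higher numbers for an effect only at larger amounts of compound:

compound 1, `COc1ccc(-c2cc(=O)c3ccc(OCCCN4CCC(C)CC4)cc3o2)cc1`, gives 26.6 nM
compound 2, `COc1ccc(-c2cc(=O)c3ccc(OCCCN4CCC(CCO)CC4)cc3o2)cc1`, gives 22.8 nM
compound 3, `COc1ccc(-c2cc(=O)c3ccc(OCCCCCCN4CCC(C)CC4)cc3o2)cc1`, gives 32.6 nM

Compound 4, `COc1ccc(-c2cc(=O)c3ccc(OCCCCCCN4CCC(CCO)CC4)cc3o2)cc1`, has not yet been measured in this assay.

The three measured compounds share a core and differ at two places. From compound 1 to compound 2 the change is hydroxymethyl in place of hydrogen on a saturated chain carbon bound to a saturated ring carbon. Along that change the read-out moved by a 1.2-fold lower number from compound 1 to compound 2 (0.07 log units; within the scatter), so the two values show no separation that can be trusted. From compound 1 to compound 3 the cores differ by 3-(4-methylpiperidin-1-yl)propyl in place of 4-methylpiperidin-1-yl on a saturated chain carbon, three bonds along the chain from an oxygen on an aromatic ring, and the step was a 1.2-fold higher number from compound 1 to compound 3 (0.09 log units; within the scatter). Compound 2 and compound 3 differ at both places at once, and the gap is a 1.4-fold higher number from compound 2 to compound 3 (0.16 log units; within the scatter); all three values sit close together.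

Compound 4 stands to compound 3 as compound 2 stands to compound 1: the change is hydroxymethyl in place of hydrogen on a saturated chain carbon bound to a saturated ring carbon, at the same place as before. Since the same change in the same place gave only a 1.2-fold lower number from compound 1 to compound 2 (0.07 log units; within the scatter) earlier, the step from compound 3 to compound 4 in this assay is expected to be about a 1.2-fold lower number from compound 3 to compound 4 (0.07 log units; within the scatter), again within the usual scatter. Starting from compound 3 with its value of 32.6 nM, compound 4 is therefore estimated to give 28 nM, with the expected range running from 15 nM to 55 nM.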

Compound 4, half-maximal effective concentration: 34.4 nM
For compound 4 the middle estimate is 1.2-fold (0.09 log units) below the measured one, within the range that was stated.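

Measured in this assay, hydroxymethyl in place of hydrogen on a saturated chain carbon bound to a saturated ring carbon gave a 1.1-fold higher number from compound 3 to compound 4 (0.02 log units; within the scatter), so on the core of compound 3 this change produced no separation that can be trusted. Set beside the earlier step on the core of compound 1, the change reads the same on both cores: the same change on two cores in this assay, a 1.2-fold lower number (0.07 log units; within the scatter) from compound 1 to compound 2 and a 1.1-fold higher number (0.02 log units; within the scatter) from compound 3 to compound 4, 1.2-fold (0.09 log units) apart, within the scatter of two such steps. This shows that, for these two pairs, the change carried from one core to the other without a step that could be told from the scatter, but it does not show that the change is without effect in general, since two small steps cannot reveal whether a larger effect would transfer in the same way, and they say nothing about other cores or about any other read-out.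

The compounds shown leave open whether a carboxylic acid or an amine in place of the 2-hydroxyethyl group of compound 4 would give a step beyond the scatter in this assay. They also leave open whether the same change would still read alike on a core with a longer chain than that of compound 4.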